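The compounds below may be only part of what the source reports. "The series", "measured", "known", "first", "only" and "open" are said of these compounds alone.

Compound 1 `N[C@H]1CC[C@H](Nc2c(C(=O)NCc3ccco3)nc(Br)c3cccnc23)CC1` gives > 10000 nM as a limit of the assay, not a number
Compound 2 `COc1cccc(CNC(=O)c2nc(Br)c3cccnc3c2N[C@H]2CC[C@H](N)CC2)c1` gives 6000 nM
Compound 3 `N[C@H]1CC[C@H](Nc2c(C(=O)NCc3ccc(Cl)cc3Cl)nc(Br)c3cccnc23)CC1` gives 6000 nM

All three were tested in a functional assay on HCT-116 cells (Homo sapiens) for cytotoxicity, read by MTT assay, with a stated time of 72 h (a higher number here means a weaker inhibitor, a lower number a stronger inhibitor), and compound 3 stands at 6000 nM there, level with compound 2 (6000 nM) on the numbers shown.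

Compound 4 `N[C@H]1CC[C@H](Nc2c(C(=O)NCc3ccc(Cl)cc3)nc(Br)c3cccnc23)CC1` has not yet been measured. It differs from compound 3 by a single change (hydrogen in place of chloro on an aromatic carbon) in which hydrogen takes the place of chloro on an aromatic carbon, ortho to a large group and meta to a chloro group, so that 2,4-dichlorobenzyl becomes 4-chlorobenzyl.

Among the compounds with values here, no measured step removes one chloro alone, so the evidence is indirect. It comes from exchanges of the whole aromatic group at the same place. The two exchanges away from furan-2-yl gave an at least 1.6-fold lower number from compound 1 to compound 2 (0.22 log units; that floor lies within the scatter) and an at least 1.6-fold lower number from compound 1 to compound 3 (0.22 log units; that floor lies within the scatter) and each of these is only a floor. The exchange of 3-methoxyphenyl for 2,4-dichlorophenyl gave no change at the digits printed from compound 2 to compound 3 (within the scatter) and is the closest guide. Resting on that step from compound 2 to compound 3, no change beyond the scatter is expected in this assay for compound 4.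

The expected step is a 1.2-fold higher number from compound 3 to compound 4 (0.07 log units; within the scatter) and it would lie within the scatter. Compound 4 is expected at 7000 nM with an estimated range from 3000 nM to 10000 nM in this assay.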

Compound 4, half-maximal inhibitory concentration: 4000 nM
Beside the measured number, compound 4's estimate is 1.8-fold (0.24 log units) above it, within the range that was stated.
By their numbers in this assay, from the lowest: compounds 4, 2 and 3 (each within the scatter of the next). At a limit, above all of these: compound 1.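

In this assay, within the data shown here, putting hydrogen in place of the chloro that sits ortho to a large group gives a 1.5-fold lower number from compound 3 to compound 4 (0.18 log units; within the scatter), the first direct reading of this single atom, and it shows that this chloro can go without a change that stands clear of the scatter. The exchange of 3-methoxyphenyl for 4-chlorophenyl gives a 1.5-fold lower number from compound 2 to compound 4 (0.18 log units; within the scatter), so compounds 2, 3 and 4 cannot be told apart in this assay, whichever of these three aromatic groups they carry. The exchange of furan-2-yl for 4-chlorophenyl gives an at least 2.5-fold lower number from compound 1 to compound 4 (0.39 log units; beyond the scatter), the first step away from furan-2-yl that clears the scatter, though it is only a floor, as compound 1 stands at a limit of the assay and not at a number: the limit of > 10000 nM in this assay, at which 1 of the 4 values shown sits.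

The compounds shown leave open whether the remaining chloro matters, which an unsubstituted benzyl group, or a methyl or bromo in place of that chloro, would show. They also leave open how a longer chain between the amide nitrogen and the ring, or a carboxylic acid on the ring, would read in this assay.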